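The source may report more compounds than this note shows. Statements on the series, on what has been measured and on what is new or still open speak of the compounds shown alone.

Measured so far in a functional assay on HepG2 cells (Homo sapiens) for antiproliferative activity, read by MTT assay, with a stated time of 72 h; a lower number here means a stronger inhibitor, a higher number a weaker inhibitor:
- compound 1 `COc1cc(CCc2ccccc2)cc(OC)c1O`: 7830 nM
- compound 2 `COc1cc(CCc2ccccc2Cl)cc(OC)c1O`: 2190 nM

Of these two compounds, compound 2 carries the lower number and is therefore the stronger inhibitor, with a gap that lies beyond the scatter. The next compound to be tested is compound 3 `COc1cc(CCc2cccc(Cl)c2Cl)cc(OC)c1O`. It keeps everything in compound 2 and makes one change: chloro in place of hydrogen on an aromatic carbon. The new chloro replaces hydrogen on an aromatic carbon, ortho to a chloro group and meta to a large group.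

Going by the values given here, only one measured step bears on this change, the same exchange of hydrogen for chloro on an aromatic carbon: a 3.6-fold lower number from compound 1 to compound 2 (0.55 log units; beyond the scatter). That step is modest, and it is a single example. Among the compounds with values here, no measurement yet shows what a further chloro does once one is already present. A step in the same direction is therefore expected in this assay, but of no greater size and possibly lost in the scatter. The expected change is a 2.2-fold lower number from compound 2 to compound 3 (0.34 log units; beyond the scatter). Compound 3 is estimated at 1000 nM, with an expected range of 350 nM to 2800 nM.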

Compound 3, half-maximal inhibitory concentration: 4770 nM
Beside the measured number, compound 3's estimate is 4.8-fold (0.68 log units) below it; the measured number lies above the stated range.
By their numbers in this assay, from the lowest: compound 2; then compounds 3 and 1 (each within the scatter of the next).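

In this assay, the exchange of hydrogen for chloro, made here on an aromatic carbon ortho to a chloro group and meta to a large group, gives a 2.2-fold higher number from compound 2 to compound 3 (0.34 log units; beyond the scatter), and this runs against the earlier 3.6-fold lower number from compound 1 to compound 2 (0.55 log units; beyond the scatter). The same exchange therefore has no single direction among these compounds: it lowers the number in the first step and raises it at this position, where a chloro group is already present, and both steps are modest yet beyond the scatter. The compounds shown offer no measurement that accounts for this reversal.

What stays open is whether the higher number belongs to this position as such or to the presence of the two chloro groups together, since no compound shown carries a chloro here with hydrogen in place of the other chloro group. From the compounds shown here alone, it also remains open whether a fluoro, methyl or methoxy group on this same aromatic carbon would move the number in the same direction as chloro or in the opposite one.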